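This account rests on a few compounds, and the source may have more. Where it says the series, first, only, none or still open, it means among the compounds named here.

Compound 1 `O=C(CCc1ccccc1-c1ccc(OCCCOc2cccc(CSCCc3ccccc3)c2)cc1)NS(=O)(=O)c1cccs1` gives 13000 nM in an assay on isolated protein for binding affinity to prostaglandin E2 receptor EP1 subtype (Homo sapiens); a higher number here means a weaker inhibitor, a lower number a stronger inhibitor.
Compound 2 `Cc1cccc(OCCCOc2ccc(-c3ccccc3CCC(=O)NS(=O)(=O)c3cccs3)cc2)c1` gives 4600 nM in this assay.

Compound 2 stands at the lower of these two numbers; the step from the other compound, a 2.8-fold lower number from compound 1 to compound 2 (0.45 log units; beyond the scatter), is modest but real. Compound 3 `Cc1cccc(OCCCOc2ccc(-c3ccccc3CC(C)C(=O)NS(=O)(=O)c3cccs3)cc2)c1` differs from compound 2 by methyl in place of hydrogen on a saturated chain carbon bound to a carbonyl carbon and a saturated chain carbon. Going by the values given here, the single measured step changed a different part of the molecule, so no measured step bears directly on this change. With nothing else to go on, the step in this assay is expected to stay within the scatter: no change at the digits printed from compound 2 to compound 3 (within the scatter). Compound 3 is therefore estimated at 4600 nM, in a range from 1500 nM to 14000 nM.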

Compound 3, inhibition constant: 5800 nM
Compound 3: the middle estimate sits 1.3-fold (0.10 log units) below what was measured; the measured number falls inside the stated range.
By their numbers in this assay, from the lowest: compounds 2 and 3 (each within the scatter of the next); then compound 1.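

Putting methyl on the saturated chain carbon bound to a carbonyl carbon and a saturated chain carbon gives a 1.3-fold higher number from compound 2 to compound 3 (0.10 log units; within the scatter) in this assay. Going by these compounds alone, this is the first reading at this position, and it shows that methyl can stand here with no change in binding beyond the scatter. No measured information bears on why the number holds.

From the compounds shown here alone, whether this tolerance extends beyond methyl remains open. A longer chain such as ethyl, or an amine or a hydroxyl on the same carbon, could behave differently.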